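The compounds below may be only part of what the source reports. "The series", "measured", "known", "first", "only" and "open" are said of these compounds alone.

Measured compounds in the series:

- compound 1 `COc1ncc(-c2ccc3ncnc(Nc4cnn(CCC(=O)O)c4)c3c2)cc1NS(C)(=O)=O`: 3840 nM
- compound 2 `COc1ncc(-c2ccc3ncnc(Nc4cnn(CC(=O)O)c4)c3c2)cc1NS(=O)(=O)c1ccc(F)cc1F`: 5200 nM
- compound 3 `COC(=O)Cn1cc(Nc2ncnc3ccc(-c4cnc(OC)c(NS(=O)(=O)c5ccc(F)cc5F)c4)cc23)cn1`: 4280 nM

In a functional assay on A549 cells (Homo sapiens) for antiproliferative activity, read by sulforhodamine B assay, with a stated time of 72 h (a higher number here means a weaker inhibitor, a lower number a stronger inhibitor), compound 1 gives 3840 nM, the smallest of the three numbers, but compound 3 and compound 2 both lie within the scatter of it, so the three compounds cannot be ranked against each other on these data.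

Compound 4 `COC(=O)CCn1cc(Nc2ncnc3ccc(-c4cnc(OC)c(NS(C)(=O)=O)c4)cc23)cn1` differs from compound 1 in one place: methyl in place of hydrogen on an oxygen next to a carbonyl group. The same change has been measured once already in this series, between compound 2 and compound 3, where it gave a 1.2-fold lower number from compound 2 to compound 3 (0.08 log units; within the scatter). For the measured compounds named here, that is the only measured step that bears on the present one, and it was not resolved from repeat scatter. There is no basis in the data for expecting the methyl ester to behave differently here than it did there, so the expectation for compound 4 in this assay is a step of about a 1.2-fold lower number from compound 1 to compound 4 (0.07 log units; within the scatter), a change that does not exceed the scatter in either direction.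

On that basis compound 4 is expected to give roughly 3300 nM in this assay, with a range of 1500 nM to 7500 nM.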

Compound 4, half-maximal inhibitory concentration: 2990 nM
For compound 4 the middle estimate is 1.1-fold (0.04 log units) above the measured one, and the stated range covers the measured number.
By their numbers in this assay, from the lowest: compounds 4, 1, 3 and 2 (each within the scatter of the next).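

In this assay, carboxy to methoxycarbonyl now has a second reading, on the core of compound 1, and it gives a 1.3-fold lower number from compound 1 to compound 4 (0.11 log units; within the scatter). Until now the change rested on a single unresolved step on one core; with compound 1 at 3840 nM and compound 4 at 2990 nM, the free acid and its methyl ester cannot be told apart on either core shown, and the size of the step does not differ between the two cores: the same change on two cores in this assay, a 1.2-fold lower number (0.08 log units; within the scatter) from compound 2 to compound 3 and a 1.3-fold lower number (0.11 log units; within the scatter) from compound 1 to compound 4, 1.1-fold (0.02 log units) apart, within the scatter of two such steps

This is a statement about two matched pairs only, and it shows that capping this oxygen with methyl leaves the number in this assay unresolved from that of the acid, not that the chain end is without influence in general. As far as these compounds go, whether a primary amide, an amine or a hydroxy group at the chain end would give a step beyond the scatter stays open. So does whether a longer chain, or a larger ester such as ethyl or tert-butyl in place of methyl, would move the number in this assay.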